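Trimming the selenium-bearing group of compound 3

A few compounds are considered here, and "the series" means these few. Any claim that something is new, unique, unknown or untested is made for them only; others in the source may bear on it.

Compound 1 `COc1ccc(N(C)c2nc(C)nc3ccccc23)cc1C(=O)OCCC[Se]C#N`: 250 nM
Compound 2 `COc1ccc(N(C)c2nc(C)nc3ccccc23)cc1C(=O)NCC[Se]C#N`: 187 nM
Compound 3 `COc1ccc(N(C)c2nc(C)nc3ccccc23)cc1C(=O)OCCCC[Se]C#N`: 155 nM

In a functional assay on A549 cells (Homo sapiens) for inhibition, read by MTT assay, with a stated time of 48 h (on this read-out lower numbers stand for stronger inhibition and higher numbers for weaker inhibition), compound 3 gives 155 nM, which cannot be separated from the other two values: the measured steps are a 1.6-fold lower number from compound 1 to compound 3 (0.21 log units; within the scatter) and a 1.2-fold lower number from compound 2 to compound 3 (0.08 log units; within the scatter). Compound 4 `COc1ccc(N(C)c2nc(C)nc3ccccc23)cc1OCC[Se]C#N` has not yet been measured. The change leading to it is a group of 6 heavy atoms (3 carbon, 1 nitrogen, 1 oxygen, 1 selenium; no ring) in place of a group of 10 heavy atoms (6 carbon, 1 nitrogen, 2 oxygen, 1 selenium; no ring), on an aromatic carbon. The remaining measured step, a 1.3-fold lower number from compound 1 to compound 2 (0.13 log units; within the scatter), also bears on this change. All three steps altered the group on a carbonyl carbon, and all stayed within the scatter. None of them removes the carbonyl, so the data offer only indirect guidance here. A step beyond the scatter is not expected, although confidence is limited, and a small move toward a higher number seems the likelier direction. The estimated step is a 1.6-fold higher number from compound 3 to compound 4 (0.21 log units; within the scatter). Compound 4 is expected at 250 nM. Compound 4 is estimated to fall between 80 nM and 800 nM.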

Compound 4, half-maximal inhibitory concentration: 13 nM
Compound 4: the middle estimate sits 19-fold (1.28 log units) above what was measured; the measured number lies below the stated range.
By their numbers in this assay, from the lowest: compound 4; then compounds 3, 2 and 1 (each within the scatter of the next).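

In this assay, the change on the aromatic carbon ortho to a methoxy group gives a 12-fold lower number from compound 3 to compound 4 (1.08 log units; beyond the scatter), together with a 14-fold lower number from compound 2 to compound 4 (1.16 log units; beyond the scatter) and a 19-fold lower number from compound 1 to compound 4 (1.28 log units; beyond the scatter), all beyond the scatter. For the compounds shown here, the earlier steps all kept the carbonyl and stayed within the scatter, so the ester and amide variants gave no sign that this position could move the number so far; the first step that removes the carbonyl and shortens the group does. Nothing available explains the size of this step.

Compound 4 differs from the others both in lacking the carbonyl and in being a smaller group, and the compounds shown cannot separate these two changes. A longer chain on the same oxygen, or an amine in place of that oxygen, would begin to tell them apart.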